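This account rests on a few compounds, and the source may have more. Where it says the series, first, only, none or still open, it means among the compounds named here.

Working notes on the series. Compound 1 `CC(C)CCC(=O)Nc1c(C(O)(C(F)(F)F)C(F)(F)F)ccc2ccccc12` and compound 2 `O=C(NCCCCCCCl)Nc1c(C(O)(C(F)(F)F)C(F)(F)F)ccc2ccccc12` share the same core and differ only at the group on the carbonyl carbon. In an assay on LtK cells with ATP-sensitive inward rectifier potassium channel 11 (Homo sapiens) as the target (on this read-out lower numbers stand for an effect already at smaller amounts and higher numbers for an effect only at larger amounts of compound), compound 1 gives 49 nM, and in this assay compound 2 gives 4840 nM, the highest of the two numbers recorded so far. Going by the values given here, the single step known, a 99-fold higher number from compound 1 to compound 2 (1.99 log units; beyond the scatter), is large and beyond the scatter.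

Compound 3 `Cc1ccc(C(=O)Nc2c(C(O)(C(F)(F)F)C(F)(F)F)ccc3ccccc23)cc1` is the next member to be measured. Relative to compound 2 the change is 4-methylphenyl in place of (6-chlorohexyl)amino on a carbonyl carbon. Among the compounds with values here, no measured step carries this exact change. Within the data shown here, the one step that bears on it, a 99-fold higher number from compound 1 to compound 2 (1.99 log units; beyond the scatter), shows that moving away from the amide of compound 1 to the urea of compound 2 cost a large amount; compound 3 returns to an amide with a ring-bearing group, so a step back toward compound 1 is expected. A large drop in this assay is therefore expected for compound 3, namely a 40-fold lower number from compound 2 to compound 3 (1.61 log units; beyond the scatter), with an estimate of 120 nM and a range of 20 nM to 900 nM.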

Compound 3, half-maximal effective concentration: 76 nM
Compound 3: the middle estimate sits 1.6-fold (0.20 log units) above what was measured; measured number inside the range.
By their numbers in this assay, from the lowest: compounds 1 and 3 (each within the scatter of the next); then compound 2.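

In this assay the group on a carbonyl carbon can be an aromatic ring as well as an open chain: the change to 4-methylphenyl from isopentyl gives a 1.6-fold higher number from compound 1 to compound 3 (0.19 log units; within the scatter) and so leaves the two groups indistinguishable here. The replacement of (6-chlorohexyl)amino by 4-methylphenyl gives a 64-fold lower number from compound 2 to compound 3 (1.80 log units; beyond the scatter) and shows that the high number of compound 2 is not shared by the other two groups at this position. No available evidence accounts for the size of this step.

The compounds shown do not separate the amino nitrogen from the chain and its chlorine as the source of that step, which a hexylamino group without chlorine or a plain hexyl chain could do. From the compounds shown here alone, how far the ring tolerates change also remains open, for example with phenyl lacking the methyl or with a carboxylic acid in its place.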